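The source may report more compounds than this note shows. Statements on the series, on what has been measured and on what is new or still open speak of the compounds shown alone.

In a functional assay on HT-1080 cells (Homo sapiens) for cytotoxicity, read by MTT assay, with a stated time of 72 h (a lower number here means a stronger inhibitor, a higher number a weaker inhibitor), compound 1 (`COc1ccc(/C=C2\CCC/C(=C\c3ccccc3Cl)C2=O)cc1OC`) gives 6800 nM and compound 2 (`COc1ccc(/C=C2\CCC/C(=C\c3ccc(OC)c(OC)c3)C2=O)cc1`) gives 7200 nM, while compound 3 (`COc1ccc(/C=C2\CCC/C(=C\c3cccc(Cl)c3Cl)C2=O)cc1OC`) gives 8800 nM, which places compound 3 within the scatter of both others. Compound 4 (`COc1cc(/C=C2\CCC/C(=C\c3ccc(OC)c(OC)c3)C2=O)ccc1O`) differs from compound 3 by a single exchange (4-hydroxy-3-methoxyphenyl in place of 2,3-dichlorophenyl on a double-bonded chain carbon bound to a double-bonded ring carbon) on a double-bonded chain carbon bound to a double-bonded ring carbon, where 4-hydroxy-3-methoxyphenyl replaces 2,3-dichlorophenyl. Among the compounds with values here, three measured steps bear on this change. One is a 1.1-fold higher number from compound 1 to compound 2 (0.02 log units; within the scatter), another is a 1.3-fold higher number from compound 1 to compound 3 (0.11 log units; within the scatter), and the third is a 1.2-fold higher number from compound 2 to compound 3 (0.09 log units; within the scatter). All three stay small and within the scatter. Within the data shown here, no measured compound carries 4-hydroxy-3-methoxyphenyl, so the new group itself remains untested and the range must stay wide. Going by these steps, no shift beyond the scatter is expected in this assay. The expected step is a 1.4-fold lower number from compound 3 to compound 4 (0.13 log units; within the scatter), with no firm direction. For compound 4 the estimated value is 6500 nM, with an expected range from 2800 nM to 14000 nM.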

Compound 4, half-maximal inhibitory concentration: 4600 nM
Compound 4: middle estimate off by 1.4-fold (0.15 log units), on the high side; measured number inside the range.
By their numbers in this assay, from the lowest: compounds 4, 1, 2 and 3 (each within the scatter of the next).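

In this assay, within the data shown here, the exchange of 2,3-dichlorophenyl for 4-hydroxy-3-methoxyphenyl on a double-bonded chain carbon bound to a double-bonded ring carbon gives a 1.9-fold lower number from compound 3 to compound 4 (0.28 log units; within the scatter) and so puts a first measured value on the new group. The same group gives a 1.6-fold lower number from compound 2 to compound 4 (0.19 log units; within the scatter) in place of 4-methoxyphenyl and a 1.5-fold lower number from compound 1 to compound 4 (0.17 log units; within the scatter) in place of 2-chlorophenyl, so none of the three new steps leaves the scatter. The entering group brings a hydrogen-bond donor and hydrogen-bond acceptors that 2,3-dichlorophenyl lacks, yet compound 4 stays within the scatter of all three earlier compounds.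

The compounds shown leave open whether an amine or a carboxylic acid on this carbon would move the number beyond the scatter. Nothing given here offers an explanation for the size of these steps.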